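A few compounds are considered here, and "the series" means these few. Any claim that something is new, unique, unknown or untested is made for them only; others in the source may bear on it.

Compound 1 `COc1cc[nH]c1/C=C1\C(=O)Nc2ccc([N+](=O)[O-])c(N3CC[C@H](O)C3)c21` gives 37 nM in a functional assay on RKO cells (Homo sapiens) for antiproliferative activity, read by MTT assay, with a stated time of 5 days; on this read-out higher numbers stand for weaker inhibition and lower numbers for stronger inhibition. Compound 2 `COc1cc[nH]c1/C=C1\C(=O)Nc2ccc([N+](=O)[O-])c(N3CC[C@@H](N)C3)c21` reaches only the assay's limit of < 10 nM in this assay, so no exact number is known for it. For the measured compounds named here, the one change measured here, an at least 3.7-fold lower number from compound 1 to compound 2 (0.56 log units; beyond the scatter), points toward a lower number on going from the hydroxy to the amino group. Compound 3 `COc1cc[nH]c1/C=C1\C(=O)Nc2ccc([N+](=O)[O-])c(N3CC[C@@H](O)C3)c21` reverses that change, with hydroxy in place of amino on a saturated ring carbon. Going back from amino to hydroxy is therefore expected to raise the number, and the step of an at least 3.0-fold higher number from compound 2 to compound 3 (0.47 log units; beyond the scatter) is estimated from the single measured step. Compound 3 is expected to give about 30 nM, plausibly between 10 nM and 100 nM.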

Compound 3, half-maximal inhibitory concentration: 32 nM
The estimate for compound 3 lay 1.1-fold (0.03 log units) below the measured number; low and high end bracket the measured number.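

Hydroxy in place of amino on this saturated ring carbon gives an at least 3.2-fold higher number from compound 2 to compound 3 (0.50 log units; beyond the scatter), so amino now stands ahead of hydroxy in both drawn configurations of the hydroxy compound. The drawn configuration at the hydroxy-bearing carbon makes no difference beyond the scatter, with a 1.2-fold lower number from compound 1 to compound 3 (0.06 log units; within the scatter): the fact that compounds 1 and 3 differ only in the configuration as drawn. Going by these compounds, compound 2 stands at a limit and not at a number, so the full size of the amino advantage stays unknown: the limit of < 10 nM in this assay, at which 1 of the 3 values shown sits.

Open, on these data alone, is how the amino compound with the opposite drawn configuration at this carbon would behave. Also open, as far as these compounds go, is what a dimethylamino group or a carboxylic acid would give at this place.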